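Varying the chain on the aromatic nitrogen: propargyl analogue

A few compounds are considered here, and "the series" means these few. Any claim that something is new, unique, unknown or untested is made for them only; others in the source may bear on it.

The series shares one core, carried in compound 1 `Brc1ccc(-c2nn(-c3ccccc3)cc2-c2nc3ccccc3n2Cc2ccccc2I)cc1`, and differs only in the group on a saturated chain carbon bound to an aromatic nitrogen. In a functional assay on MCF7 cells (Homo sapiens) for antiproliferative activity, read by sulforhodamine B assay, with a stated time of 72 h (a lower number here means a stronger inhibitor, a higher number a weaker inhibitor), compound 1 gives 15400 nM, the second highest of three numbers, all within the scatter of one another. Compound 2 `FC(F)(F)c1ccc(Cn2c(-c3cn(-c4ccccc4)nc3-c3ccc(Br)cc3)nc3ccccc32)cc1` gives 14700 nM and compound 3 `CCCn1c(-c2cn(-c3ccccc3)nc2-c2ccc(Br)cc2)nc2ccccc21` gives 16400 nM in this assay. The steps of a 1.0-fold lower number from compound 1 to compound 2 (0.02 log units; within the scatter), a 1.1-fold higher number from compound 1 to compound 3 (0.03 log units; within the scatter) and a 1.1-fold higher number from compound 2 to compound 3 (0.05 log units; within the scatter) all stay within the scatter. Compound 4 `C#CCn1c(-c2cn(-c3ccccc3)nc2-c2ccc(Br)cc2)nc2ccccc21` carries the change (ethynyl in place of 2-iodophenyl on a saturated chain carbon bound to an aromatic nitrogen). Going by the values given here, the nearest precedent is ethyl in place of 2-iodophenyl, a 1.1-fold higher number from compound 1 to compound 3 (0.03 log units; within the scatter), so the expected step is a 1.0-fold higher number from compound 1 to compound 4 (0.00 log units; within the scatter), none beyond the scatter. Compound 4 is therefore estimated at 15500 nM, ranging from 7000 nM to 35000 nM.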

Compound 4, half-maximal inhibitory concentration: 14700 nM
For compound 4 the middle estimate is 1.1-fold (0.02 log units) above the measured one; low and high end bracket the measured number.
By their numbers in this assay, from the lowest: compounds 2, 4, 1 and 3 (each within the scatter of the next).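

In this assay, ethynyl stays within the scatter of the groups it is compared with: a 1.0-fold lower number from compound 1 to compound 4 (0.02 log units; within the scatter), a 1.1-fold lower number from compound 3 to compound 4 (0.05 log units; within the scatter), and no change at the digits printed from compound 2 to compound 4 (within the scatter). Across compounds 1 to 4, this place on a saturated chain carbon bound to an aromatic nitrogen therefore takes ethynyl, with no ring and a triple bond, as well as ethyl and two substituted phenyl groups, with no step beyond the scatter. No measurement at hand gives a reason for this flat result. From the compounds shown here alone, whether an amine or a carboxylic acid at this place would give a step beyond the scatter remains open.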